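The source may report more compounds than this note shows. Statements on the series, on what has been measured and on what is new or still open speak of the compounds shown alone.

Measured so far in a functional assay on HEK293 cells for agonist activity at probable G-protein coupled receptor 27 (Homo sapiens), read by a luciferase reporter and beta-arrestin recruitment, with a stated time of 10 min; on this read-out lower numbers stand for smaller maximal responses and higher numbers for larger maximal responses:
- compound 2, `O=C(Nc1ccc(S(=O)(=O)Nc2ccccc2)cc1)c1ccc(Cl)cc1Br`: 123%
- compound 3, `O=C(Nc1ccc(S(=O)(=O)Nc2ccccc2)cc1)c1cc2ccccc2oc1=O`: 53%
- compound 1, `O=C(Nc1ccc(Cl)cc1Cl)c1ccc(S(=O)(=O)Nc2ccccc2)cc1`: "not determined" (no result reported)

Notes on the series. Three compounds share the sulfonamide-bearing core, and only two of them carry a number in this assay. Compound 2 gives 123%, the highest of the two numbers shown. Compound 3 gives 53%, which is far lower, and the gap between compound 2 and compound 3 lies well beyond the usual scatter of repeated measurements. Compound 1 has no result in this assay, so nothing can be said about it beyond its structure. Within the data shown here, no step between two measured compounds differing in a single place is available, so the effect of changing the aryl group on the carbonyl carbon can only be read from the two values shown.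

The next compound is compound 4, `Cc1cc(Br)ccc1C(=O)Nc1ccc(S(=O)(=O)Nc2ccccc2)cc1`. It differs from compound 2 in one place: 4-bromo-2-methylphenyl in place of 2-bromo-4-chlorophenyl on a carbonyl carbon. Both aryl groups are halogenated phenyl rings of equal size, so a large loss such as that seen with compound 3 is not expected. The step from compound 2 is estimated as a moderate decrease, a number 28 percentage points lower from compound 2 to compound 4 (beyond the scatter), of a size that may or may not exceed the scatter. Compound 4 is therefore expected to give 95% in this assay, within a range of 55% to 135%.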

Compound 4, largest response reached (Emax), in percent of the reference or control that the assay uses: 103%
Beside the measured number, compound 4's estimate is 8 percentage points below it; low and high end bracket the measured number.
By their numbers in this assay, from the lowest: compound 3; then compound 4; then compound 2.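

In this assay, among these compounds, the exchange of 2-bromo-4-chlorophenyl for 4-bromo-2-methylphenyl on a carbonyl carbon gives the first step that can be read at a single place: a number 20 percentage points lower from compound 2 to compound 4 (beyond the scatter), a modest change that still lies beyond the scatter. This position therefore responds to a change between two phenyl groups with the same count of heavy atoms, yet compound 4 still reaches 103%, so a large maximal response does not depend on the exact 2-bromo-4-chlorophenyl group. The step exchanges chlorine for a methyl group and also changes where the bromine sits, so it cannot assign the change to any one of these groups.

Still open, on these data alone, is how a plain unsubstituted phenyl, a 4-bromophenyl, or a phenyl bearing a carboxylic acid or an amine would behave at this place, and whether the phenyl on the sulfonamide nitrogen tolerates change at all. No available evidence bears on why the response shifts with this exchange.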